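From Methoxy to Acetamido on the Shared Core

The source may report more compounds than this note shows. Statements on the series, on what has been measured and on what is new or still open speak of the compounds shown alone.

- Compound 1 `COc1c(OC)c(OC(C)=O)c2ccccc2c1OC(C)=O`: 2.39
- Compound 2 `COc1c(OC)c(OC(C)=O)c2c(OC)cccc2c1OC(C)=O`: 2.43

In a physicochemical assay for lipophilicity (on this read-out lower numbers stand for lower lipophilicity and higher numbers for higher lipophilicity), compound 2 at 2.43 lies within the scatter of compound 1 at 2.39. Compound 3 `COc1c(OC)c(OC(C)=O)c2c(NC(C)=O)cccc2c1OC(C)=O` has acetamido in place of methoxy on an aromatic carbon. For the measured compounds named here, the only measured step, a number 0.04 log units higher from compound 1 to compound 2 (within the scatter), stayed within the scatter, but it involved methoxy and hydrogen. Going by the values given here, no measured step involves acetamido, so this expectation is uncertain. A downward step in this assay is expected, estimated as a number 0.73 log units lower from compound 2 to compound 3 (beyond the scatter). For compound 3, the estimate is 1.7, with an expected range of 1.2 to 2.2.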

Compound 3, partition coefficient: 2
For compound 3 the middle estimate is 0.30 log units below the measured one, and the stated range covers the measured number.
By their numbers in this assay, from the lowest: compound 3; then compounds 1 and 2 (each within the scatter of the next).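

In this assay, acetamido in place of methoxy gives a number 0.43 log units lower from compound 2 to compound 3 (beyond the scatter), and acetamido in place of hydrogen gives a number 0.39 log units lower from compound 1 to compound 3 (beyond the scatter). So this position on the shared core can register a change of group, which compound 1 and compound 2 did not show, since those two lie within the scatter of each other. Nothing measured here gives a reason for these steps. Still open, on these data alone, is how an amine or a carboxylic acid on this aromatic carbon would read, and whether a longer chain in place of acetamido would give a similar number.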